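This account rests on a few compounds, and the source may have more. Where it says the series, first, only, none or still open, it means among the compounds named here.

Measured compounds:
- compound 1 `CCc1cccc(NC(=O)CN2CCN(c3ccccn3)CC2)c1` gives 370 nM in an assay on cells for antagonist activity at D(4) dopamine receptor (Homo sapiens), read by luminescence and beta-arrestin recruitment, with a stated time of 90 min; a lower number here means a stronger inhibitor, a higher number a weaker inhibitor
- compound 2 `O=C(CN1CCN(c2ccccn2)CC1)Nc1cccnc1` gives 25800 nM in this assay

Compound 2 holds the higher of the two numbers in this assay; its nearest neighbour is compound 1, separated by the step of a 70-fold higher number from compound 1 to compound 2 (1.84 log units; beyond the scatter), which is large and beyond the scatter. Compound 3 `O=C(CN1CCN(c2ccccn2)CC1)Nc1cncnc1` differs from compound 2 by pyrimidin-5-yl in place of pyridin-3-yl on an amide-type nitrogen. Within the data shown here, no measured step matches this exact change. Among the measured compounds shown here, the only step available, a 70-fold higher number from compound 1 to compound 2 (1.84 log units; beyond the scatter), swapped a carbon ring for a ring with one nitrogen at the same amide-type nitrogen and weakened inhibition markedly, so the direction is suggestive but the size cannot be read across. Compound 3 is therefore expected to sit near compound 2 or somewhat weaker, with a 1.7-fold higher number from compound 2 to compound 3 (0.24 log units; within the scatter) as the estimated step. The estimate for compound 3 in this assay is 45000 nM, between 15000 nM and 130000 nM.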

Compound 3, half-maximal inhibitory concentration: "not active" (no number reported)
No number was reported for compound 3, and the estimate cannot be compared.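

Among these compounds, compound 3 was reported as "not active" without a number in this assay, so no step from compound 2 to compound 3 can be read. The compounds shown leave open how large the change from pyridin-3-yl to pyrimidin-5-yl is. No supporting evidence bears on this result.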